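Replacing pyridin-2-yl with the other 1-(4-acetamidophenyl)ethyl

A few compounds are considered here, and "the series" means these few. Any claim that something is new, unique, unknown or untested is made for them only; others in the source may bear on it.

Measured so far:
compound 1 `O=S(=O)(NCC1CCN(CCCc2c[nH]c3ccc(-n4cnnc4)cc23)CC1)c1ccccc1` gives 6.2 nM
compound 2 `CC(=O)Nc1ccc([C@H](C)NCC2CCN(CCCc3c[nH]c4ccc(-n5cnnc5)cc34)CC2)cc1` gives 0.6 nM
compound 3 `c1ccc(NCC2CCN(CCCc3c[nH]c4ccc(-n5cnnc5)cc34)CC2)nc1` gives 1.7 nM

All three share one core and differ only in the group on an amine nitrogen. In an assay on CHO cells for displacement of a labelled ligand from 5-hydroxytryptamine receptor 1D (Homo sapiens) (on this read-out lower numbers stand for stronger inhibition and higher numbers for weaker inhibition), compound 3 stands second highest of the three numbers: a 2.8-fold higher number from compound 2 to compound 3 (0.45 log units; beyond the scatter), and a 3.6-fold lower number from compound 1 to compound 3 (0.56 log units; beyond the scatter).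

Compound 4 `CC(=O)Nc1ccc([C@@H](C)NCC2CCN(CCCc3c[nH]c4ccc(-n5cnnc5)cc34)CC2)cc1` is not yet measured. From compound 3 the change is 1-(4-acetamidophenyl)ethyl in place of pyridin-2-yl on an amine nitrogen. Compound 4 and compound 2 carry the same group, set differently at its one stereocentre.

The step that bears most directly is the reverse of the measured one: a 2.8-fold higher number from compound 2 to compound 3 (0.45 log units; beyond the scatter). Turned around, it suggests a step toward a lower number. Also a 10-fold lower number from compound 1 to compound 2 (1.01 log units; beyond the scatter) shows this group giving the lowest number seen. Nothing measured says how the other arrangement at the stereocentre behaves, so the expectation is held looser than for compound 2 itself. Compound 4 is therefore expected to give 1.5 nM, within 0.4 nM to 6 nM, meaning an estimated step of a 1.1-fold lower number from compound 3 to compound 4 (0.05 log units; within the scatter).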

Compound 4, half-maximal inhibitory concentration: 1.5 nM
Compound 4: middle estimate and measured number agree at the digits printed, and the stated range covers the measured number.
By their numbers in this assay, from the lowest: compound 2; then compounds 4 and 3 (each within the scatter of the next); then compound 1.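

In this assay, the arrangement at the single stereocentre of 1-(4-acetamidophenyl)ethyl matters, giving a 2.5-fold higher number from compound 2 to compound 4 (0.40 log units; beyond the scatter), and that step can be traced to the stereocentre alone because of this: the fact that compounds 2 and 4 differ only in the configuration as drawn. The low number of compound 2 therefore does not come from the atoms of this group alone: in the other arrangement, swapping pyridin-2-yl for this group gives only a 1.1-fold lower number from compound 3 to compound 4 (0.05 log units; within the scatter). Against phenylsulfonyl on the same amine nitrogen, the group still goes with a lower number in this arrangement, with a 4.1-fold lower number from compound 1 to compound 4 (0.62 log units; beyond the scatter), though that step is smaller than a 10-fold lower number from compound 1 to compound 2 (1.01 log units; beyond the scatter).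

The compounds shown leave open which part of the group, the acetamide or the methyl at the stereocentre, makes the arrangement count. A plain benzyl group, or a 1-phenylethyl group without the acetamide, on this nitrogen would help separate the two.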